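From pyridin-4-yl to quinolin-3-yl on a shared core

A few compounds are considered here, and "the series" means these few. Any claim that something is new, unique, unknown or untested is made for them only; others in the source may bear on it.

Measured in a functional assay on NCI-H1993 cells (Homo sapiens) for inhibition, read by CCK-8 assay, with a stated time of 72 h; on this read-out higher numbers stand for weaker inhibition and lower numbers for stronger inhibition:
Compound 1 `CC(c1c(F)cc2ncccc2c1F)n1cnc2ncc(-c3cnn(CCO)c3)nc21`: 83.7 nM
Compound 2 `CC(c1c(F)cc2ncccc2c1F)n1cnc2ncc(-c3ccncc3)nc21`: 162 nM

Among the compounds with values here, compound 2 stands within the scatter of compound 1, the only other compound measured, so the two cannot be ranked. Compound 3 `CC(c1c(F)cc2ncccc2c1F)n1cnc2ncc(-c3cnc4ccccc4c3)nc21` carries quinolin-3-yl in place of the pyridin-4-yl of compound 2 on an aromatic carbon: quinolin-3-yl in place of pyridin-4-yl on an aromatic carbon. Within the data shown here, one measured step bears on this change, as it concerns the same aromatic carbon: a 1.9-fold higher number from compound 1 to compound 2 (0.29 log units; within the scatter). Among the measured compounds shown here, that exchange of one aromatic group for another stayed within the scatter, but it is a single step, and no measured compound carries quinolin-3-yl. No step beyond the scatter is therefore expected in this assay, although the data are too few for a narrow range. The expected step is a 1.1-fold lower number from compound 2 to compound 3 (0.03 log units; within the scatter). For compound 3 the estimated value is 150 nM, with an expected range from 50 nM to 450 nM.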

Compound 3, half-maximal inhibitory concentration: 46.1 nM
Compound 3: the middle estimate sits 3.3-fold (0.51 log units) above what was measured; the measured number lies below the stated range.
By their numbers in this assay, from the lowest: compounds 3, 1 and 2 (each within the scatter of the next, the first and the last beyond it).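

In this assay, within the data shown here, this aromatic carbon of the shared core now gives a step beyond the scatter, as quinolin-3-yl in place of pyridin-4-yl produces a 3.5-fold lower number from compound 2 to compound 3 (0.55 log units; beyond the scatter) while the only earlier step had stayed within it. Set against the 1-(2-hydroxyethyl)-1H-pyrazol-4-yl group, quinolin-3-yl gives a 1.8-fold lower number from compound 1 to compound 3 (0.26 log units; within the scatter) and so cannot be ranked against it, which shows that this position accepts the two-ring group without any weaker inhibition. Nothing measured here explains the step.

Going by these compounds, it remains open whether the ring nitrogen of quinolin-3-yl matters, a question that naphthalen-2-yl would address. Also open, on these data alone, is how a methoxy group or a morpholine attached to the quinolin-3-yl would read in this assay.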